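Ethyl ester in place of a free acid on cytotoxicity

The source may report more compounds than this note shows. Statements on the series, on what has been measured and on what is new or still open speak of the compounds shown alone.

Measured compounds:
compound 1 `Cc1nc(C)c(C(=O)Oc2ccccc2/C=C/C(=O)O)nc1C` gives 80.1%
compound 2 `Cc1nc(C)c(C(=O)Oc2ccc(Cl)cc2/C=C/C(=O)O)nc1C` gives 52.2%

Of the compounds shown here, two have so far been tested in a functional assay on EA.hy 926 cells (Homo sapiens) for cytotoxicity, read by MTT assay, with stated times of 24 h and 12 h, tested at 100 uM; on this read-out higher numbers stand for a stronger effect at the one concentration tested and lower numbers for a weaker effect. Compound 1 gives 80.1% in this assay, while compound 2 gives 52.2%. For the measured compounds named here, the single measured step, a number 27.9 percentage points lower from compound 1 to compound 2 (beyond the scatter), places compound 2 as the lower of the two numbers, its nearest neighbour being compound 1.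

Compound 3 `CCOC(=O)/C=C/c1cc(Cl)ccc1OC(=O)c1nc(C)c(C)nc1C` has not yet been measured. It differs from compound 2 by ethyl in place of hydrogen on an oxygen next to a carbonyl group. Among the measured pairs, only the step of a number 27.9 percentage points lower from compound 1 to compound 2 (beyond the scatter) exists, and it concerns a chloro in place of hydrogen on an aromatic carbon, a change at a different part of the molecule; it therefore offers no guide to what an ethyl in place of hydrogen on the oxygen next to the carbonyl group will do in this assay. With nothing comparable in hand, the plainest expectation is a step of no clear size in either direction, and the estimate is accordingly kept close to compound 2 with a wide range.

Compound 3 is expected to give about 52% in this assay, within a range from 28% to 76%. This estimate corresponds to an expected step of a number 0.2 percentage points lower from compound 2 to compound 3 (within the scatter).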

Compound 3, a percentage reported as activity, at one concentration (the size of the read-out at that concentration, not a potency): 11%
Compound 3: the middle estimate sits 41 percentage points above what was measured, outside the stated range (below it).
By their numbers in this assay, from the lowest: compound 3; then compound 2; then compound 1.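

In this assay, the change on the oxygen next to a carbonyl group, from hydrogen to ethyl, turns the carboxy group into ethoxycarbonyl and gives a number 41.2 percentage points lower from compound 2 to compound 3 (beyond the scatter), so this position clearly bears on the read-out. The earlier pair spoke only to chloro in place of hydrogen on an aromatic carbon, with a number 27.9 percentage points lower from compound 1 to compound 2 (beyond the scatter), and said nothing about this end of the molecule; compound 3 now stands lowest of the three, and each of the two single changes has lowered the number. Nothing at hand explains why the ethyl group has this effect.

The ethyl step has been seen only with the chloro group present, so the compounds shown leave open whether the same change would lower the number by a similar size on compound 1, which carries hydrogen at that aromatic carbon. They also leave open whether the effect follows from capping the acid as such or from ethyl in particular, which a methyl ester, a longer chain on the same oxygen or an amide in place of the ester would help to separate.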